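Sulfonyl aryl swap in a series sitting at the limit

This account rests on a few compounds, and the source may have more. Where it says the series, first, only, none or still open, it means among the compounds named here.

Measured so far in an assay on cells for inhibition of HSP60/HSP10 (Homo sapiens), with a stated time of 60 min; a lower number here means a stronger inhibitor, a higher number a weaker inhibitor:
compound 1 `O=S(=O)(Nc1ccc2oc(-c3ccccc3)nc2c1)c1cccc(F)c1` gives > 100000 nM, a limit of the assay and not a number.
compound 2 `O=S(=O)(Nc1ccc2oc(-c3ccccc3)nc2c1)c1ccccc1F` gives > 100000 nM, likewise a limit, not a number.

For the measured compounds named here, compound 2 thus stands only as a limit in this assay; the one other value shown, for compound 1, is a limit as well. The measured step that the two limits leave unreadable from compound 1 to compound 2 has no readable size, both ends resting at the limit (the limit of > 100000 nM in this assay, at which 2 of the 2 values shown sit). The change to compound 3 `O=S(=O)(Nc1ccc2oc(-c3ccccc3)nc2c1)c1cccc(Cl)c1` is 3-chlorophenyl in place of 2-fluorophenyl on a sulfonyl sulfur. Going by the values given here, the only measured step concerns the same sulfonyl position, yet it cannot show whether exchanging or moving the halogen shifts the read-out, so no direction can be drawn from it. Because compound 2 gives > 100000 nM, compound 3 is expected to remain at the same limit. The expected step of a number no higher from compound 2 to compound 3 (the limit leaves the size open) is therefore none beyond the scatter. The estimate for compound 3 in this assay is 100000 nM, with a range from 30000 nM to 300000 nM, most likely again reported only as a limit.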

Compound 3, half-maximal inhibitory concentration: > 100000 nM
Compound 3: a limit, no number; the forecaster's own chance of this, stated with the estimate: 80%; the middle value sits exactly at the limit.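

In this assay compound 3 gives > 100000 nM, a limit and not a number. For the compounds shown here, no step among compound 1, compound 2 and compound 3 can be read, all three resting at the same limit: the limit of > 100000 nM in this assay, at which 3 of the 3 values shown sit. The compounds shown leave open whether any halogen swap or shift on this sulfonyl aryl group changes the read-out.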